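Swapping Piperidine for a Bridged Amine on the Shared Core

The source may hold more compounds than are shown below. What is called first, only, known or untested is meant among the compounds shown, and "the series" means these compounds.

Compound 1 `O=C(CCc1ccc(C(F)(F)F)cc1)Nc1ccc2nc(N3CC4CC3CN4)ccc2c1`: 210 nM
Compound 2 `O=C(CCc1ccc(C(F)(F)F)cc1)Nc1ccc2nc(N3CCCCC3)ccc2c1`: 12 nM

Within the data shown here, in an assay on isolated protein for displacement of a labelled ligand from melanin-concentrating hormone receptor 1 (Homo sapiens) (on this read-out lower numbers stand for stronger inhibition and higher numbers for weaker inhibition), compound 2 holds the lower of the two numbers measured so far, with compound 1 sitting well above it. Compound 3 `O=C(CCc1ccc(C(F)(F)F)cc1)Nc1ccc2nc(N3CC4CCC3C4)ccc2c1` carries a group of 7 heavy atoms (6 carbon, 1 nitrogen; one five-membered non-aromatic ring of carbon only, one five-membered non-aromatic ring with 1 hetero atom) in place of a group of 6 heavy atoms (5 carbon, 1 nitrogen; one six-membered non-aromatic ring with 1 hetero atom), on an aromatic carbon. Among the measured compounds shown here, the only measured step, an 18-fold lower number from compound 1 to compound 2 (1.24 log units; beyond the scatter), also exchanged a bicyclic group for piperidin-1-yl, but that earlier group is not the one entering compound 3, so the step bears on it only loosely. A modest weakening is therefore expected, a 1.8-fold higher number from compound 2 to compound 3 (0.26 log units; within the scatter). Compound 3 is estimated at 22 nM, between 6 nM and 80 nM.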

Compound 3, half-maximal inhibitory concentration: 1 nM
Beside the measured number, compound 3's estimate is 22-fold (1.34 log units) above it, outside the stated range (below it).
By their numbers in this assay, from the lowest: compound 3; then compound 2; then compound 1.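

In this assay the new bridged group gives a 12-fold lower number from compound 2 to compound 3 (1.08 log units; beyond the scatter), so piperidin-1-yl does not mark the best result available at this position on the shared core. Bridging alone does not decide the outcome: the two bridged groups have different atoms, and moving to the one with a single nitrogen gives a 210-fold lower number from compound 1 to compound 3 (2.32 log units; beyond the scatter). No measurement here explains either step. Still open, from the compounds shown here alone, is how a smaller pyrrolidine ring, a morpholine ring or a larger bridged amine would fare at this position.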